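This account rests on a few compounds, and the source may have more. Where it says the series, first, only, none or still open, it means among the compounds named here.

Two compounds of this series share one core and differ only by a single fluoro group. Compound 1 is `O=c1c2cc(F)ccc2ccn1[C@@H]1O[C@H](COP(=O)(O)OP(=O)(O)OP(=O)(O)O)[C@@H](O)[C@H]1O`. In a functional assay for agonist activity at P2Y purinoceptor 6 (Homo sapiens), read by FLIPR (on this read-out lower numbers stand for an effect already at smaller amounts and higher numbers for an effect only at larger amounts of compound), compound 1 gives > 20000 nM, which is a limit of the assay and not a number. Compound 2 is `O=c1c2cc(F)c(F)cc2ccn1[C@@H]1O[C@H](COP(=O)(O)OP(=O)(O)OP(=O)(O)O)[C@@H](O)[C@H]1O`, carrying fluoro in place of hydrogen on an aromatic carbon. In this assay compound 2 gives > 20000 nM, again a limit rather than a number. The step that the two limits leave unreadable from compound 1 to compound 2 therefore cannot be read in size, because both values sit at the limit of > 20000 nM in this assay, at which 2 of the 2 values shown sit. Compound 2 thus stands at a limit, and nothing measured places it anywhere more precisely. Compound 3 is `CSc1cc2ccn([C@@H]3O[C@H](COP(=O)(O)OP(=O)(O)OP(=O)(O)O)[C@@H](O)[C@H]3O)c(=O)c2cc1F`. Going from compound 2 to compound 3 means (methylsulfanyl in place of fluoro on an aromatic carbon). Among the compounds with values here, no measured step bears on this exchange; the only step known is unreadable, so there is no ground for expecting a change beyond the scatter in either direction. The expected step is a number no higher from compound 2 to compound 3 (the limit leaves the size open), most likely leaving compound 3 at a limit as well. Compound 3 is estimated at 20000 nM in this assay, within a range from 5000 nM to 80000 nM.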

Compound 3, half-maximal effective concentration: > 20000 nM
Compound 3: a limit, no number; the forecaster's own chance of this, stated with the estimate: 75%; the middle value sits exactly at the limit.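

In this assay compound 3 gives > 20000 nM, which is a limit of the assay and not a number. No step among compound 1, compound 2 and compound 3 can be read in size, because all three values sit at the same limit: the limit of > 20000 nM in this assay, at which 3 of the 3 values shown sit.

The compounds shown leave open how far each lies beyond that limit, and whether hydrogen, fluoro or methylsulfanyl at this place makes any difference.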